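The source may hold more compounds than are shown below. What is called first, only, known or untested is meant among the compounds shown, and "the series" means these compounds.

Measured in a functional assay on HEL cells (Homo sapiens) for cytotoxicity; on this read-out higher numbers stand for lower toxicity in this test and lower numbers for higher toxicity in this test:
- compound 1, `CCC(C)C(NC(=O)n1nnc2ccccc21)C(=O)NC1CCCCC1`: 80 ug/mL
- compound 2, `CCC(C)C(NC(=O)n1nnc2ccccc21)C(=O)NCc1ccccc1`: 200 ug/mL
- compound 3, `CCC(C)C(NC(=O)n1nnc2ccccc21)C(=O)NC1CCCC1`: >= 80 ug/mL, a limit of the assay and not a number

Compound 1 sits at the lowest of the two numbers in this assay. Its nearest neighbour is compound 2, reached by a 2.5-fold higher number from compound 1 to compound 2 (0.40 log units; beyond the scatter) with benzyl in place of cyclohexyl on the amide-type nitrogen. Compound 3 gives only (the limit of >= 80 ug/mL in this assay, at which 1 of the 3 values shown sits); the step of a number no lower from compound 1 to compound 3 (the limit leaves the size open) therefore cannot be sized, and the same holds for a step that the limit leaves unreadable from compound 2 to compound 3.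

Compound 4, `CC(C)C(NC(=O)n1nnc2ccccc21)C(=O)NC1CCCCC1`, is the next point. It differs from compound 1 by hydrogen in place of methyl on a saturated chain carbon, three bonds along the chain from an amide-type nitrogen and a carbonyl carbon. Within the data shown here, every step measured so far alters the group on the amide-type nitrogen; none touches the saturated chain carbon where this change sits, so no measured step speaks directly to it. The change removes a single carbon from the side chain and leaves the core, the amide and the nitrogen substituent untouched. On that basis the expected outcome is no change at the digits printed from compound 1 to compound 4 (within the scatter), a step within the usual scatter. For compound 4 the estimate in this assay is 80 ug/mL, with a range from 40 ug/mL to 200 ug/mL; a limit rather than a number, as seen for compound 3, remains possible.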

Compound 4, minimum cytotoxic concentration: >= 80 ug/mL
Compound 4 gave a limit, no number (the forecaster's own chance of this, stated with the estimate: 30%); the middle value sits exactly at the limit.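

In this assay, among these compounds, hydrogen in place of methyl on a saturated chain carbon, three bonds along the chain from an amide-type nitrogen and a carbonyl carbon, is the first change away from the group on the amide-type nitrogen, and it gives a number no lower from compound 1 to compound 4 (the limit leaves the size open). Compound 4 gives >= 80 ug/mL, a limit of the assay and not a number, so this step and the comparisons of compound 4 with the other compounds cannot be sized; the result shows only that going from sec-butyl to isopropyl brings no lower number. Compound 3 and compound 4, which differ from compound 1 in different places, now end at the same limit: the limit of >= 80 ug/mL in this assay, at which 2 of the 4 values shown sit.

The compounds shown leave open how far the true value of compound 4 lies from that of compound 1, and so whether the change has any effect at all on this read-out. They also leave open what a longer chain, or a side chain ending in an amine or a carboxylic acid, would do in place of the sec-butyl group.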